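A few compounds are considered here, and "the series" means these few. Any claim that something is new, unique, unknown or untested is made for them only; others in the source may bear on it.

Series notes, step from compound 2 to compound 3.

Two members of the series have numbers in a functional assay on cells for antagonist activity at Neuropeptide Y receptor type 5 (Homo sapiens); a lower number here means a stronger inhibitor, a higher number a weaker inhibitor. Compound 1 `CC(=O)NC[C@H]1CC[C@H](Nc2nc(Nc3ccc(Cl)cc3)c3ccccc3n2)CC1` gives 390 nM in this assay. Compound 2 `CNC[C@H]1CC[C@H](Nc2nc(Nc3ccc(Cl)cc3)c3ccccc3n2)CC1` gives 510 nM in this assay. Among the compounds with values here, the one measured step, a 1.3-fold higher number from compound 1 to compound 2 (0.12 log units; within the scatter), is a methyl in place of acetyl on the amine nitrogen and changes nothing beyond the scatter. On the numbers shown, compound 2 stands at the higher of the two, with compound 1 within the scatter of it, so no order between them can be read.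

Compound 3 `CC(=O)N(C)C[C@H]1CC[C@H](Nc2nc(Nc3ccc(Cl)cc3)c3ccccc3n2)CC1` is not yet measured. It differs from compound 2 by acetyl in place of hydrogen on an amine nitrogen. Among the measured steps, only the step from compound 1 to compound 2 bears on it, since it moves between the same acetyl and methyl substituents on the same nitrogen and was within the scatter; compound 3 carries both groups on that nitrogen at once. Within the data shown here, no measured step combines the two, so the expectation rests on the indifference seen so far. Compound 3 is therefore expected to sit close to compound 2, an estimated step of a 1.1-fold lower number from compound 2 to compound 3 (0.05 log units; within the scatter) in this assay, not beyond the scatter. The estimate for compound 3 in this assay is 450 nM, with a range from 180 nM to 1200 nM.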

Compound 3, half-maximal inhibitory concentration: 58 nM
For compound 3 the middle estimate is 7.8-fold (0.89 log units) above the measured one; the measured number lies below the stated range.
By their numbers in this assay, from the lowest: compound 3; then compounds 1 and 2 (each within the scatter of the next).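

In this assay this nitrogen proves far from indifferent, although the earlier exchange of acetyl for methyl on it stayed within the scatter: acetyl in place of hydrogen on the methylamino nitrogen gives an 8.8-fold lower number from compound 2 to compound 3 (0.94 log units; beyond the scatter), and methyl in place of hydrogen on the amide-type nitrogen gives a 6.7-fold lower number from compound 1 to compound 3 (0.83 log units; beyond the scatter). Neither substituent alone accounts for the lower number, as compound 1 and compound 2 cannot be ordered, and only compound 3, with the acetyl(methyl)amino group, stands apart, so on these three compounds the contributions of acetyl and methyl do not add independently. Nothing available explains this difference.

The compounds shown leave open whether the acetyl itself is required or whether the absence of a hydrogen on this nitrogen is sufficient, a question that a dimethylamino group would help to separate from the acetyl(methyl)amino group. Also open, from the compounds shown here alone, is how far the nitrogen tolerates larger groups, such as ethyl in place of the methyl or propionyl in place of the acetyl.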